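The source may report more compounds than this note shows. Statements on the series, on what has been measured and on what is new or still open speak of the compounds shown alone.

Measured so far:
compound 1 `CCCCCCCCc1ccc(OCC(=O)Cn2nnc(SC)n2)cc1`: 31 nM
compound 2 `CCCCCCCCc1ccc(OCC(=O)Cn2nnc(-c3ccc(S(=O)(=O)N(C)C)cc3)n2)cc1`: 590 nM
compound 3 `CCCCCCCCc1ccc(OCC(=O)Cn2nnc(-c3ccccn3)n2)cc1`: 18 nM

In an assay on microsomes from brain for inhibition of Fatty-acid amide hydrolase 1 (Rattus norvegicus), read by fluorescence and HPLC, with a stated time of 60 min (on this read-out lower numbers stand for stronger inhibition and higher numbers for weaker inhibition), compound 1 stands second highest of the three numbers. Its nearest neighbour is a step within the scatter, a 1.7-fold lower number from compound 1 to compound 3 (0.24 log units; within the scatter), whereas the other is large, a 19-fold higher number from compound 1 to compound 2 (1.28 log units; beyond the scatter). Compound 4 `CCCCCCCCc1ccc(OCC(=O)Cn2nnc(-c3cccs3)n2)cc1` differs from compound 1 in one place: thiophen-2-yl in place of methylsulfanyl on an aromatic carbon. The step to compound 3 bears most on this, since there too a ring replaced methylsulfanyl and the number barely moved; the large step to compound 2 came from a quite different replacement. For compound 4 a step within the scatter is therefore expected in this assay: a 1.4-fold lower number from compound 1 to compound 4 (0.15 log units; within the scatter). Compound 4 is estimated at 22 nM, between 8 nM and 60 nM.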

Compound 4, half-maximal inhibitory concentration: 32 nM
For compound 4 the middle estimate is 1.5-fold (0.16 log units) below the measured one, within the range that was stated.
By their numbers in this assay, from the lowest: compounds 3, 1 and 4 (each within the scatter of the next); then compound 2.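

At this position on the ring with four nitrogens, thiophen-2-yl proves as acceptable as methylsulfanyl (a 1.0-fold higher number from compound 1 to compound 4 (0.01 log units; within the scatter)) and as pyridin-2-yl (a 1.8-fold higher number from compound 3 to compound 4 (0.25 log units; within the scatter)). Two different aromatic rings now match the small group, so a ring here does not by itself cost inhibition, whereas 4-(dimethylsulfamoyl)phenyl stands well apart (an 18-fold lower number from compound 2 to compound 4 (1.27 log units; beyond the scatter)). Nothing available explains these numbers.

The compounds shown leave open whether the loss with compound 2 comes from its phenyl ring or from its dimethylsulfamoyl group. A plain phenyl ring at this position would separate the two.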